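Methylsulfonylphenyl Regioisomer in a Series Without Readable Activity

The compounds below may be only part of what the source reports. "The series", "measured", "known", "first", "only" and "open" are said of these compounds alone.

Compound 2 (`O=C(Nc1ccc(Cl)c(-c2nnc3c(Cl)cccn23)c1)c1cccnc1Cl`) carries a 2-chloropyridin-3-yl on its carbonyl carbon. In a functional assay on AN3-CA cells (Homo sapiens) for antiproliferative activity, read by MTT assay, with a stated time of 72 h (on this read-out lower numbers stand for stronger inhibition and higher numbers for weaker inhibition), compound 2 gives only a limit, > 100000 nM, and no number. Compound 1 (`CS(=O)(=O)c1ccc(C(=O)Nc2ccc(Cl)c(-c3nnc4c(Cl)cccn34)c2)cc1`) likewise gives only a limit in this assay, > 100000 nM. Going by the values given here, the one step measured so far, a step that the two limits leave unreadable from compound 1 to compound 2, cannot be read in size because the limit of > 100000 nM in this assay, at which 2 of the 2 values shown sit, holds both values, so nothing is known about how much the group on the carbonyl carbon shifts potency.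

Compound 3 (`CS(=O)(=O)c1cccc(C(=O)Nc2ccc(Cl)c(-c3nnc4c(Cl)cccn34)c2)c1`) differs from compound 2 by 3-(methylsulfonyl)phenyl in place of 2-chloropyridin-3-yl on a carbonyl carbon. Among the compounds with values here, the only measured step that touches this place is the unreadable one from compound 1 to compound 2, so no measured size guides the expectation. Compound 3 shares its methylsulfonylphenyl amide type with compound 1, which sits at the limit. Compound 3 is therefore expected to give about 100000 nM in this assay, somewhere within 30000 nM to 300000 nM, most likely again as a limit. The expected step, a number no higher from compound 2 to compound 3 (the limit leaves the size open), amounts to nothing beyond the scatter.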

Compound 3, half-maximal inhibitory concentration: > 100000 nM
Compound 3: a limit, no number (the forecaster's own chance of this, stated with the estimate: 75%); the middle value sits exactly at the limit.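

No new step can be read: the steps joining compound 3 to compound 2 and to compound 1 have no readable size, because all three compounds give only a limit in this assay: the limit of > 100000 nM in this assay, at which 3 of the 3 values shown sit.

The compounds shown leave open whether any group on the carbonyl carbon gives a readable value in this series.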